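This account rests on a few compounds, and the source may have more. Where it says the series, first, only, none or still open, it means among the compounds named here.

Measured so far:
- compound 1 `O=S(=O)(CC1=NCCO1)C1C(c2ccc(Cl)cc2)=NN(c2ccccc2)C1c1ccc(Cl)cc1`: "not active" (no number reported)
- compound 2 `COc1ccc(C2=NN(c3ccccc3)C(c3ccc(C)cc3)C2S(=O)(=O)CC2=NCCS2)cc1`: 50.7%
- compound 3 `COc1ccc(-c2nn(-c3ccccc3)c(-c3ccc(C)cc3)c2S(=O)(=O)CC2=NCCO2)cc1`: 68.2%

In a functional assay, read by Griess assay, with a stated time of 150 min, tested at 100 ug/mL (on this read-out higher numbers stand for a stronger effect at the one concentration tested and lower numbers for a weaker effect), compound 1 gives "not active" (no number reported), so no single number marks where it stands; it is reported only as showing no effect. Compound 2 gives 50.7% and compound 3 gives 68.2% in this assay, but both differ from compound 1 in several places, so no single step can be read from them. Compound 4 `O=S(=O)(CC1=NCCS1)C1C(c2ccc(Cl)cc2)=NN(c2ccccc2)C1c1ccc(Cl)cc1` is not yet measured. It differs from compound 1 in one place: a group of 5 heavy atoms (3 carbon, 1 nitrogen, 1 sulfur; one five-membered non-aromatic ring with 2 hetero atoms) in place of a group of 5 heavy atoms (3 carbon, 1 nitrogen, 1 oxygen; one five-membered non-aromatic ring with 2 hetero atoms), on a saturated chain carbon bound to a sulfonyl sulfur. Among the measured compounds shown here, with no measured step of this kind, the expected change is small, likely within the scatter. Compound 4 is therefore estimated at 20%, with a range from 0% to 50%.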

Compound 4, a percentage reported as activity, at one concentration (the size of the read-out at that concentration, not a potency): "not active" (no number reported)
For compound 4 the study gives words and no number, and the estimate cannot be compared.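

In this assay compound 1 gives "not active" (no number reported) and compound 4 gives "not active" (no number reported), so no step can be read between them. The compounds shown leave open whether exchanging oxygen for sulfur in the five-membered ring changes a measurable effect. Nothing shown offers an explanation for these results.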